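The compounds below may be only part of what the source reports. "The series", "measured", "known", "first", "only" and "open" are said of these compounds alone.

In a functional assay on NCI-H522 cells (Homo sapiens) for cytotoxicity, with a stated time of 3 days (a higher number here means a weaker inhibitor, a lower number a stronger inhibitor), three compounds have been measured so far. Compound 1 `C=Cc1csc(Br)n1` carries a vinyl group and a bromo group on its core. In this assay compound 1 gives > 40000 nM, which is a limit of the assay and not a number. Compound 2 `C=Cc1nc(C(=O)OCC)cs1` carries the same vinyl group on a core that bears a group of 5 heavy atoms; how the two cores differ is not broken down here. In this assay compound 2 gives > 40000 nM, again a limit of the assay. Compound 3 `C#Cc1nc(C(=O)OCC)cs1` differs from compound 2 by a single change, (ethynyl in place of vinyl on an aromatic carbon). In this assay compound 3 gives 2670 nM. That change made an at least 14-fold lower number from compound 2 to compound 3 (1.17 log units; beyond the scatter), a large step, read against (the limit of > 40000 nM in this assay, at which 2 of the 3 values shown sit).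

Compound 4 `C#Cc1csc(Br)n1` has not yet been measured. It stands to compound 1 as compound 3 stands to compound 2: ethynyl in place of vinyl on an aromatic carbon. The two changes are of the same kind rather than the same, since in compound 2 the carbon that bears the group is next to the ring sulfur and two ring bonds from the ring atom that bears a group of 5 heavy atoms, whereas in compound 1 it is two ring bonds from the ring sulfur and two ring bonds from the ring atom that bears a bromo group. Compound 1 gives only a limit, so the starting point is not known as a number. On the strength of an at least 14-fold lower number from compound 2 to compound 3 (1.17 log units; beyond the scatter) a step in the same direction is expected, estimated as an at least 5.0-fold lower number from compound 1 to compound 4 (0.69 log units; beyond the scatter). Compound 4 is therefore expected to give 8000 nM in this assay, within 1500 nM to 40000 nM.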

Compound 4, half-maximal inhibitory concentration: > 40000 nM
Compound 4: no number, only a limit (the forecaster's own chance of this, stated with the estimate: 35%); at least 5.0-fold (0.69 log units) between middle value and limit.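

In this assay compound 4 gives > 40000 nM, which is a limit of the assay and not a number. Compound 1 sits at the same kind of limit, so no step between compound 1 and compound 4 can be read: the limit of > 40000 nM in this assay, at which 3 of the 4 values shown sit.

The compounds shown leave open whether ethynyl in place of vinyl changes the true potency at all on the core of compound 1.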